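Swapping a Chain for a Small Aromatic Ring on the Amide

This account rests on a few compounds, and the source may have more. Where it says the series, first, only, none or still open, it means among the compounds named here.

In an assay on isolated protein for inhibition of ribosomal protein S6 kinase beta-1 (Homo sapiens), read by HTRF, tested at 10 uM (a higher number here means more inhibition at the concentration tested (going by the name of the read-out), a lower number less inhibition), compound 1 `CC(=O)CCCCC(=O)N1CCN(c2nccc(Oc3cccc(C)c3)n2)CC1` gives 3%, and compound 2 `COC[C@@H]1CCCN1C(=O)C1CCCN1c1cc(Nc2cccc(Br)c2)ncn1` gives 3%, so the two stand level within the usual scatter of this assay. Compound 3 `Cc1cccc(Oc2ccnc(N3CCN(C(=O)c4c(C)noc4C)CC3)n2)c1` differs from compound 1 in one place: 3,5-dimethyl-1,2-oxazol-4-yl in place of 4-acetylbutyl on a carbonyl carbon. Going by the values given here, no measured pair shows a step of this kind, so nothing beyond the scatter can be expected from it, and compound 3 is estimated to stay near the number of compound 1, a step of a number 2 percentage points higher from compound 1 to compound 3 (within the scatter). Compound 3 is therefore expected to give about 5%, likely between -10% and 25%.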

Compound 3, a percentage reported as inhibition, at one concentration (the size of the read-out at that concentration, not a potency): 5%
Beside the measured number, compound 3's estimate shows no gap at the digits printed; the range from low to high includes it.
By their numbers in this assay, from the lowest: compounds 1, 2 and 3 (each within the scatter of the next).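

In this assay, the change from the open 4-acetylbutyl chain to the aromatic 3,5-dimethyl-1,2-oxazol-4-yl ring on this carbonyl carbon is a number 2 percentage points higher from compound 1 to compound 3 (within the scatter). This first step at the position therefore separates a chain from a ring in no measurable way, and both compounds remain low at the single concentration tested. No supporting measurement offers any explanation for this result.

On these data alone, whether a group at this position can raise inhibition at all remains open. A phenyl ring, a basic amine or a carboxylic acid on the same carbonyl would be a further test.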